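The source may hold more compounds than are shown below. What is called first, only, known or untested is meant among the compounds shown, and "the series" means these compounds.

Four compounds are considered here, all built on a shared core: compound 1 `COc1cccc(/C=C2\CCC/C(=C\c3cccc(Cl)c3Cl)C2=O)c1OC`, compound 2 `COc1ccc(/C=C2\CCC/C(=C\c3cccc(OC)c3OC)C2=O)c(OC)c1`, compound 3 `COc1ccc(/C=C2\CCC/C(=C\c3ccc(Br)cc3)C2=O)cc1OC` and compound 4 `COc1ccc(/C=C2\CCC/C(=C\c3ccc(O)c(O)c3)C2=O)cc1OC`. In a functional assay on SW-620 cells (Homo sapiens) for cytotoxicity, read by MTT assay, with a stated time of 72 h (a lower number here means a stronger inhibitor, a higher number a weaker inhibitor), compound 1 gives 16300 nM. For compound 2 this assay returns only a limit, > 20000 nM, so no number is known for it. Compound 3 gives 5200 nM in this assay, the lowest of the two numbers measured; compound 1 sits at a higher number, and that gap lies beyond the usual scatter. Compound 4 has not yet been measured.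

The change from compound 3 to compound 4 is 3,4-dihydroxyphenyl in place of 4-bromophenyl on a double-bonded chain carbon bound to a double-bonded ring carbon. Among the measured compounds shown here, no pair among the measured compounds differs in one place only, so no measured step speaks directly to this change; the swap of a halogen-bearing ring for a hydroxyl-bearing ring is of a kind the existing numbers do not cover. Given that, in this assay a modest step toward a higher number, somewhat beyond the scatter, is expected from the change a 1.7-fold higher number from compound 3 to compound 4 (0.24 log units; within the scatter). Compound 4 is therefore expected to give about 9000 nM in this assay, with a likely range from 2500 nM to 25000 nM.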

Compound 4, half-maximal inhibitory concentration: 10500 nM
Beside the measured number, compound 4's estimate is 1.2-fold (0.07 log units) below it; the measured number falls inside the stated range.
By their numbers in this assay, from the lowest: compound 3; then compounds 4 and 1 (each within the scatter of the next). At a limit, above all of these: compound 2.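

In this assay, among the compounds shown here, the new pair gives the first comparison that differs in one place only, and it shows a modest loss at this position on a double-bonded chain carbon bound to a double-bonded ring carbon: a 2.0-fold higher number from compound 3 to compound 4 (0.31 log units; beyond the scatter). Replacing 4-bromophenyl with 3,4-dihydroxyphenyl removes the bromine and brings in 2 hydrogen-bond donors and 2 hydrogen-bond acceptors, yet compound 4 still returns a real number, 10500 nM, rather than a limit. Nothing measured here bears on why the number moves in this direction.

This single step joins two events, the departure of the bromine and the arrival of two hydroxyl groups, and the compounds shown cannot separate them, so it remains unknown how much of the step belongs to each. On these data alone, it also remains open whether a phenyl ring carrying an amine or a carboxylic acid at this place would stay close to compound 3 or compound 4, and whether the same swap would give a step of similar size with a different group at the other end of the shared core.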